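A few compounds are considered here, and "the series" means these few. Any claim that something is new, unique, unknown or untested is made for them only; others in the source may bear on it.

Compound 1 `Cc1ccccc1COc1cc(O)c2c(=O)c(O)c(-c3ccccc3)oc2c1` is a flavonol whose core carries a 2-methylbenzyl ether. In an ADME assay on Huh-5-2 cells (Homo sapiens) for cytotoxicity, read by WST assay, with a stated time of 3 days (a higher number here means that more compound is tolerated, a lower number that less compound is tolerated), compound 1 gives 17000 nM, the lowest of the two numbers recorded so far. Among the measured compounds shown here, its only measured neighbour is compound 2 `N#Cc1cccc(COc2cc(O)c3c(=O)c(O)c(-c4ccccc4)oc3c2)c1`, which differs in the group on the saturated chain carbon bound to an oxygen on an aromatic ring; in this assay compound 2 gives 72000 nM. For the measured compounds named here, the one recorded step, a 4.2-fold higher number from compound 1 to compound 2 (0.63 log units; beyond the scatter), shows that swapping the ring at this place can move the number by a modest amount toward more tolerated.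

Compound 3 `COc1ccc(COc2cc(O)c3c(=O)c(O)c(-c4ccccc4)oc3c2)cc1` is not yet measured. It differs from compound 1 as follows: 4-methoxyphenyl in place of 2-methylphenyl on a saturated chain carbon bound to an oxygen on an aromatic ring. Going by the values given here, this is again a change of the ring at the same place as in the step from compound 1 to compound 2, and that step is the only guide. A change of similar kind, though not identical, is expected to give a small to modest rise, so a 1.8-fold higher number from compound 1 to compound 3 (0.25 log units; within the scatter) is estimated. Compound 3 is therefore expected to give about 30000 nM in this assay, within a range from 12000 nM to 75000 nM.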

Compound 3, half-maximal cytotoxic concentration: > 100000 nM
Compound 3 ended at the assay's limit; the forecaster's own chance of this, stated with the estimate: 10%; at least 3.3-fold (0.52 log units) between middle value and limit.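

In this assay compound 3 gives > 100000 nM, which is a limit of the assay and not a number: the limit of > 100000 nM in this assay, at which 1 of the 3 values shown sits.

Replacing 2-methylphenyl on the saturated chain carbon bound to an oxygen on an aromatic ring with 4-methoxyphenyl gives an at least 5.8-fold higher number from compound 1 to compound 3 (0.76 log units; beyond the scatter), so a second ring group at this place also moves the result toward more compound being tolerated, and the full size of this move stays hidden behind the limit. The comparison of the two replacement groups is less firm: the step is an at least 1.3-fold higher number from compound 2 to compound 3 (0.14 log units; that floor lies within the scatter), so 3-cyanophenyl and 4-methoxyphenyl cannot yet be put in order.

The change from 2-methylphenyl to 4-methoxyphenyl alters both the group and where it sits on the ring, so the compounds shown cannot say which of the two matters; 4-methylphenyl and 2-methoxyphenyl at this place would separate them. It also remains open whether a ring carrying an amine or a carboxylic acid would follow the same direction as the three ring groups shown.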